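The compounds below may be only part of what the source reports. "The series", "measured", "known", "first", "only" and "open" are said of these compounds alone.

Compound 2 `O=C(O)CC1COc2cc(OCc3cccc(-c4csc5ccccc45)c3)ccc21` is one of two analogues measured in an assay on CHO cells for displacement of a labelled ligand from Free fatty acid receptor 1 (Rattus norvegicus), read by scintillation counting, with a stated time of 90 min, in the presence of a further agent that is not named here; a higher number here means a weaker inhibitor, a lower number a stronger inhibitor. In this assay compound 2 gives > 10000 nM, a limit of the assay and not a number. Compound 1 `Cc1cccc(C)c1-c1cccc(COc2ccc3c(c2)CC3CC(=O)O)c1`, which carries a 2,4-dimethylphenyl on a different core, likewise gives only > 10000 nM, again a limit. Both values therefore rest at the limit of > 10000 nM in this assay, at which 2 of the 2 values shown sit. Compound 3 `Cc1ccc(-c2cccc(COc3ccc4c(c3)OCC4CC(=O)O)c2)c(C)c1` differs from compound 2 by 2,4-dimethylphenyl in place of 1-benzothiophen-3-yl on an aromatic carbon. For the measured compounds named here, no measured step exists for this change; since compound 1 with the same 2,4-dimethylphenyl shows > 10000 nM, no gain beyond the scatter is expected in this assay, so the step that the limit leaves unreadable from compound 2 to compound 3 is estimated to stay near the limit. Compound 3 is expected to give about 15000 nM, in the range 5000 nM to 50000 nM, most likely reported only as a limit.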

Compound 3, inhibition constant: 1600 nM
Compound 3: middle estimate off by 9.4-fold (0.97 log units), on the high side, outside the stated range (below it).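

On the shared core, the place on the six-membered aromatic ring meta to a large group responds to the aryl group in this assay: 2,4-dimethylphenyl in place of 1-benzothiophen-3-yl gives an at least 6.2-fold lower number from compound 2 to compound 3 (0.79 log units; beyond the scatter). Compound 3 is the only compound shown with a number and not a limit, so this change gives the first readable binding in the series. The true size of the step remains open-ended, since compound 2 sits at a limit: the limit of > 10000 nM in this assay, at which 2 of the 3 values shown sit.

As far as these compounds go, whether a plain phenyl or a pyridine ring at this place would match compound 3 remains open. The separate contribution of each methyl group is also unresolved.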